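Methyl to tert-butyl on a double-bonded nitrogen

The compounds below may be only part of what the source reports. "The series", "measured", "known", "first", "only" and "open" are said of these compounds alone.

Of the compounds shown here, three have been measured in an ADME assay on cells (Peritoneal macrophage, Mus musculus, strain BALB/c) for cytotoxicity, read by fluorescence and resazurin assay, with a stated time of 72 h; on this read-out higher numbers stand for lower toxicity in this test and lower numbers for higher toxicity in this test. Compound 1 (`O=Cc1ccc([N+](=O)[O-])s1`) gives 6250 nM, compound 2 (`O=[N+]([O-])c1ccc(/C=[N+](\[O-])Cc2ccccc2)s1`) gives 18500 nM and compound 3 (`C/[N+]([O-])=C/c1ccc([N+](=O)[O-])s1`) gives 24200 nM. Compound 3 therefore sits at the upper end of these numbers, within the scatter of compound 2. The gap on the other side is a 3.9-fold higher number from compound 1 to compound 3 (0.59 log units; beyond the scatter).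

Compound 4 (`CC(C)(C)/[N+]([O-])=C/c1ccc([N+](=O)[O-])s1`) has not yet been measured. The change is tert-butyl in place of methyl on a double-bonded nitrogen.

The closest evidence is a 1.3-fold higher number from compound 2 to compound 3 (0.12 log units; within the scatter), hydrogen in place of phenyl on a saturated chain carbon bound to a double-bonded nitrogen. That step alters the same side of the molecule and stays within the scatter. The larger step from the first comparison involves a different change and bears only weakly on this one. No branched group on this nitrogen has been measured, so the range is kept wide.

No step beyond the scatter is expected in this assay. The estimated step is a 1.2-fold lower number from compound 3 to compound 4 (0.08 log units; within the scatter). The estimated value for compound 4 is 20000 nM, with an expected range from 9000 nM to 45000 nM.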

Compound 4, half-maximal cytotoxic concentration: 29800 nM
Estimate against measurement, compound 4: 1.5-fold (0.17 log units) below, and the stated range covers the measured number.
By their numbers in this assay, from the lowest: compound 1; then compounds 2, 3 and 4 (each within the scatter of the next).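

In this assay, among these compounds, the first branched group on this nitrogen gives a 1.2-fold higher number from compound 3 to compound 4 (0.09 log units; within the scatter), so tert-butyl in place of methyl leaves the read-out unresolved from that of the methyl compound. Before this result, the only comparison on this side of the molecule was a 1.3-fold higher number from compound 2 to compound 3 (0.12 log units; within the scatter); with compound 4 included, both steps among compound 2, compound 3 and compound 4 stay within the scatter, and the only step beyond it remains a 3.9-fold higher number from compound 1 to compound 3 (0.59 log units; beyond the scatter), which involves a different change. The data at hand offer no measured basis for explaining why the tert-butyl change produces so small a step.

On these data alone, it remains open whether a longer chain, a cyclohexyl ring, or a substituent carrying an amine or a carboxylic acid on this nitrogen would also stay within the scatter of compound 3 in this assay. The compounds shown also leave open whether replacing the nitro group on the shared core would change the read-out more than the changes on this nitrogen have so far.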